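A few compounds are considered here, and "the series" means these few. Any claim that something is new, unique, unknown or untested is made for them only; others in the source may bear on it.

Compound 1, `C/N=C(\NC#N)Nc1cccnc1`: in a functional assay on the whole organism (blood, strain Wistar-Okamoto) with Rattus norvegicus as the target, with a stated time of 5 days (a higher number here means that more compound is needed for the effect, a lower number that less compound is needed), compound 1 gives > 50 mg/kg, which is a limit of the assay rather than a number.
Compound 2, `CC(C)CC/N=C(\NC#N)Nc1cccnc1`: in this assay compound 2 gives 20 mg/kg.
Compound 3, `CCCC(C)(C)/N=C(\NC#N)Nc1cccnc1`: in this assay compound 3 gives 1 mg/kg.

Compound 3 stands lowest of the two numbers shown, needing the least compound; its nearest neighbour is compound 2, with a 20-fold lower number from compound 2 to compound 3 (1.30 log units; beyond the scatter) between them. Compound 4, `N#CN/C(=N\c1ccccc1)Nc1cccnc1`, has not yet been measured. It differs from compound 3 in one place: phenyl in place of 1,1-dimethylbutyl on a double-bonded nitrogen. For the measured compounds named here, two measured steps concern a change on the same double-bonded nitrogen: they gave an at least 50-fold lower number from compound 1 to compound 3 (1.69 log units; beyond the scatter) and a 20-fold lower number from compound 2 to compound 3 (1.30 log units; beyond the scatter), both large. Going by the values given here, the group on this nitrogen therefore matters a great deal, but no measured compound carries a ring there, so the direction for phenyl is open. Since compound 3 already holds the lowest number and both large steps ended at it, a move back upward seems more likely than a further drop. Compound 4 is expected to give about 10 mg/kg, between 2 mg/kg and 50 mg/kg. This estimate means an expected step of a 10-fold higher number from compound 3 to compound 4 (1.00 log units; beyond the scatter).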

Compound 4, minimum effective dose: 5 mg/kg
Compound 4: middle estimate off by 2.0-fold (0.30 log units), on the high side; the measured number falls inside the stated range.
By their numbers in this assay, from the lowest: compound 3; then compound 4; then compound 2. At a limit, above all of these: compound 1.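

A ring can sit on this double-bonded nitrogen and the effect remains, although phenyl, with the same count of heavy atoms as the 1,1-dimethylbutyl it replaces, gives a 5.0-fold higher number from compound 3 to compound 4 (0.70 log units; beyond the scatter). Phenyl in place of isopentyl gives a 4.0-fold lower number from compound 2 to compound 4 (0.60 log units; beyond the scatter), so the two open chains fall on either side of the ring, and a ring does not simply rank above or below a chain at this position. Phenyl in place of methyl gives an at least 10-fold lower number from compound 1 to compound 4 (1.00 log units; beyond the scatter), and that step starts from a limit of the assay rather than a number: the limit of > 50 mg/kg in this assay, at which 1 of the 4 values shown sits.

From the compounds shown here alone, it remains open whether a saturated ring such as cyclohexyl would behave more like phenyl or like 1,1-dimethylbutyl. Also open, going by these compounds, is how a chlorine atom or a methoxy group on the phenyl ring would shift the dose needed.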